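Removing the Chlorine from Compound 2

The source may report more compounds than this note shows. Statements on the series, on what has been measured and on what is new or still open speak of the compounds shown alone.

Going by the values given here, compound 2 `CCC(C(=O)N1CCN(c2cccc(Cl)c2)CC1)N1C(=O)CCC1=O` is the stronger of the two compounds measured so far in a functional assay on the whole organism (strain Swiss) with Mus musculus as the target, in the maximal electroshock model, with a stated time of 2 h, at a dose of 300 mg/kg by the intraperitoneal route; on this read-out higher numbers stand for a stronger effect at the one dose given and lower numbers for a weaker effect. In this assay compound 2 gives 25%, while compound 1 `CCC(C(=O)N1CCN(c2ccc(F)cc2)CC1)N1C(=O)CCC1=O` gives 0%. Among the compounds with values here, the one measured step, a number 25 percentage points higher from compound 1 to compound 2 (beyond the scatter), joins these two. Compound 3 `CCC(C(=O)N1CCN(c2ccccc2)CC1)N1C(=O)CCC1=O` has not yet been tested. The change from compound 2 to compound 3 is hydrogen in place of chloro on an aromatic carbon. Within the data shown here, no measured step removes a halogen from this ring; the single step available swaps one halogen-bearing phenyl for another and was modest, so it bears on this change only loosely. A modest fall rather than a rise is expected, because compound 2 reaches only 25% and nothing measured shows a gain from a bare phenyl. The expected step is a number 15 percentage points lower from compound 2 to compound 3 (beyond the scatter). Compound 3 is therefore estimated at 10%, within a range from 0% to 30%.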

Compound 3, a percentage reported as activity, at one dose (the size of the read-out at that dose, not a potency): 25%
Compound 3: the middle estimate sits 15 percentage points below what was measured, within the range that was stated.
By their numbers in this assay, from the lowest: compound 1; then compounds 2 and 3 (each within the scatter of the next).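

In this assay the chloro group on the ring proves not to be needed at this place: the read-out shows no change at the digits printed from compound 2 to compound 3 (within the scatter) when hydrogen replaces it. The bare phenyl also separates from the fluorinated compound, with a number 25 percentage points higher from compound 1 to compound 3 (beyond the scatter) in the same comparison, so among these three compounds the low number goes with the 4-fluorophenyl group alone and not with the absence of chlorine. No measurement here explains why these groups give these numbers.

As far as these compounds go, what remains open is whether a different group on this aromatic carbon, such as methoxy or an amine, would move the read-out away from that of the bare phenyl. Also open, from the compounds shown here alone, is whether the low number of compound 1 depends on the fluoro group itself or on where it sits on the ring.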